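This account rests on a few compounds, and the source may have more. Where it says the series, first, only, none or still open, it means among the compounds named here.

Measured compounds:
compound 1 `Cc1nc(S(C)(=O)=O)ccc1Oc1ncnc(OC2CCN(C(=O)OC3COC3)CC2)c1F` — 326 nM
compound 2 `Cc1nc(S(C)(=O)=O)ccc1Oc1ncnc(OC2CCN(C(=O)OC3(C(F)(F)F)CCC3)CC2)c1F` — 14.3 nM
compound 3 `Cc1nc(S(C)(=O)=O)ccc1Oc1ncnc(OC2CCN(C(=O)C(C)(C)F)CC2)c1F` — 76.3 nM

All three share one core and differ only in the group attached to the carbonyl carbon of the piperidine amide. In a functional assay on isolated protein for inhibition of Glucose-dependent insulinotropic receptor (Homo sapiens), read by HTRF and cAMP accumulation (on this read-out higher numbers stand for an effect only at larger amounts of compound and lower numbers for an effect already at smaller amounts), compound 3 gives 76.3 nM, the second highest of the three numbers: compound 1 sits higher (a 4.3-fold lower number from compound 1 to compound 3 (0.63 log units; beyond the scatter)), and compound 2 sits lower (a 5.3-fold higher number from compound 2 to compound 3 (0.73 log units; beyond the scatter)). Compound 4 `CCc1cnc(C(=O)N2CCC(Oc3ncnc(Oc4ccc(S(C)(=O)=O)nc4C)c3F)CC2)nc1` changes that same position: 5-ethylpyrimidin-2-yl in place of 1-fluoro-1-methylethyl on a carbonyl carbon. Among the measured compounds shown here, two measured steps bear on it, since both swapped the group on this carbonyl carbon: a 4.3-fold lower number from compound 1 to compound 3 (0.63 log units; beyond the scatter) and a 5.3-fold higher number from compound 2 to compound 3 (0.73 log units; beyond the scatter), each modest, while the widest step among the three, a 23-fold lower number from compound 1 to compound 2 (1.36 log units; beyond the scatter), shows that this position can move the number a great deal. For the measured compounds named here, compound 4 carries a group closer in size to that of compound 2 than to that of compound 3, so a modest drop is expected, a 1.9-fold lower number from compound 3 to compound 4 (0.28 log units; within the scatter), though none of the measured groups is aromatic. Compound 4 is therefore expected to give about 40 nM in this assay, within a range of 12 nM to 130 nM.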

Compound 4, half-maximal effective concentration: 4.7 nM
The estimate for compound 4 lay 8.5-fold (0.93 log units) above the measured number; the measured number lies below the stated range.
By their numbers in this assay, from the lowest: compound 4; then compound 2; then compound 3; then compound 1.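

Compound 4 shows that an aromatic ring, 5-ethylpyrimidin-2-yl, can sit on this carbonyl carbon and give the lowest number of the four in this assay: a 16-fold lower number from compound 3 to compound 4 (1.21 log units; beyond the scatter), and a 69-fold lower number from compound 1 to compound 4 (1.84 log units; beyond the scatter). The step of a 3.0-fold lower number from compound 2 to compound 4 (0.48 log units; beyond the scatter) is smaller but still beyond the scatter, and the group of compound 4 has fewer heavy atoms than the group of compound 2, so the lowest number here does not come with the largest group. Nothing measured here explains why this ring gives such a low number.

The compounds shown leave open whether the drop goes with the ring nitrogens, the ethyl chain or the aromatic ring itself. A phenyl ring or a 5-methylpyrimidin-2-yl group on the same carbonyl carbon would help separate these.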